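The source may report more compounds than this note shows. Statements on the series, on what has been measured and on what is new or still open speak of the compounds shown alone.

Measured in a functional assay on OVCAR-5 cells (Homo sapiens) for inhibition, read by CCK-8 assay, with a stated time of 72 h, tested at 1 uM; on this read-out higher numbers stand for more inhibition of growth at the one concentration tested and lower numbers for less inhibition of growth:
- compound 1 `CN(C)C(=O)c1cc2cnc(Nc3ccc(NC(=O)C4(C(=O)Nc5ccccc5F)CC4)cc3)nc2n1C1CCCC1`: 58%
- compound 2 `CN(C)C(=O)c1cc2cnc(Nc3ccc(NC(=O)C4(C(=O)Nc5ccc(Br)cc5)CC4)cc3)nc2n1C1CCCC1`: 13.7%

Of these two, compound 2 stands lowest, at 13.7%. Compound 3 `CN(C)C(=O)c1cc2cnc(Nc3ccc(NC(=O)C4(C(=O)Nc5cccc(Br)c5)CC4)cc3)nc2n1C1CCCC1` is still unmeasured in this assay. It differs from compound 2 as follows: 3-bromophenyl in place of 4-bromophenyl on an amide-type nitrogen. In words, it carries 3-bromophenyl in place of 4-bromophenyl on an amide-type nitrogen. Within the data shown here, only one measured step bears on this change: a number 44.3 percentage points lower from compound 1 to compound 2 (beyond the scatter). That step is large, but it replaced 2-fluorophenyl, so it offers no direct measure of a change that keeps the bromine. Among the measured compounds shown here, no measured compound carries 3-bromophenyl. A modest recovery from the low value of compound 2 seems the likeliest outcome, though the evidence is thin. The expected step is a number 16.3 percentage points higher from compound 2 to compound 3 (beyond the scatter), smaller than the measured one. The estimate for compound 3 is 30%, with an expected range of 12% to 52%.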

Compound 3, percent growth inhibition at one concentration: 0.04%
Compound 3: the middle estimate sits 30 percentage points above what was measured; the measured number lies below the stated range.
By their numbers in this assay, from the lowest: compound 3; then compound 2; then compound 1.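

With the same atoms joined differently, exchanging 4-bromophenyl for 3-bromophenyl on the amide-type nitrogen in this assay gives a number 13.7 percentage points lower from compound 2 to compound 3 (beyond the scatter), so the placement of the bromine alone changes the result beyond the scatter. Against the 2-fluorophenyl group, 3-bromophenyl gives a number 58 percentage points lower from compound 1 to compound 3 (beyond the scatter), leaving both bromophenyl compounds far under compound 1 and making compound 3 the lowest of the three. Nothing available explains why these groups differ. 

The compounds shown leave open whether the gap between compound 1 and the two bromophenyl compounds follows the halogen or its placement, since 2-bromophenyl, 3-fluorophenyl and 4-fluorophenyl are not among them. They also leave open how an unsubstituted phenyl, or a phenyl ring bearing a methoxy group or a nitrile, would compare at this amide-type nitrogen.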